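Replacing One Aryl Group on a Shared Core

This account rests on a few compounds, and the source may have more. Where it says the series, first, only, none or still open, it means among the compounds named here.

Within the data shown here, compound 2 `O=C(CN1CCN(c2cccc(C(F)(F)F)c2)CC1)N(c1ccccc1)c1ccccc1` is the only member of this small set with a full number: in a functional assay on the whole organism (strain Swiss albino) for inhibition, with Mus musculus as the target, with stated times of 10 min, 5 min and 20 min (on this read-out lower numbers stand for an effect already at smaller amounts and higher numbers for an effect only at larger amounts of compound), compound 2 gives 21.3 mg/kg. Compound 1 `Cc1ccc(N2CCN(CC(=O)N(c3ccccc3)c3ccccc3)CC2)cc1` differs from it only in the aryl group on the ring nitrogen, and for compound 1 this assay reports a limit, > 20 mg/kg. Among the measured compounds shown here, the step that the limit leaves unreadable from compound 1 to compound 2 therefore has no readable size, and the sole evidence on the measured pair is the limit of > 20 mg/kg in this assay, at which 1 of the 2 values shown sits. Compound 3 `COc1ccccc1N1CCN(CC(=O)N(c2ccccc2)c2ccccc2)CC1` carries a further change at the same place: 2-methoxyphenyl in place of 3-(trifluoromethyl)phenyl on an amine nitrogen in a ring. For the measured compounds named here, no measured step with a readable size speaks to this change, so nothing beyond the usual scatter is expected in either direction. Compound 3 is expected to give 25 mg/kg in this assay, within a range from 10 mg/kg to 60 mg/kg. This estimate means an expected step of a 1.2-fold higher number from compound 2 to compound 3 (0.07 log units; within the scatter). For compound 3 a reported limit instead of a number also remains a real possibility.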

Compound 3, dose for half-maximal effect: 8.2 mg/kg
Compound 3: middle estimate off by 3.0-fold (0.48 log units), on the high side; measured number outside the range, below it.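

Among these compounds, this place on the ring nitrogen responds to the choice of aryl group: in this assay, the change to 2-methoxyphenyl gives a 2.6-fold lower number from compound 2 to compound 3 (0.41 log units; beyond the scatter), the first step in the set with a readable size. The change from 4-methylphenyl to 2-methoxyphenyl points the same way, with an at least 2.4-fold lower number from compound 1 to compound 3 (0.38 log units; beyond the scatter). That second step is only a minimum, since compound 1 is reported as a limit and not as a number: the limit of > 20 mg/kg in this assay, at which 1 of the 3 values shown sits.

With only these three aryl groups, the data cannot separate the effect of having a methoxy group from the effect of where it sits on the aromatic ring. They also leave open how a 3-methoxyphenyl or 2-chlorophenyl group, or an aryl group bearing an amine or a carboxylic acid, would behave in this assay.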